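Permeability across a carbonyl-linked variation in a shared core

A few compounds are considered here, and "the series" means these few. Any claim that something is new, unique, unknown or untested is made for them only; others in the source may bear on it.

Measured so far:
- compound 1, `Cc1cc(-c2ccnc3[nH]c(-c4cnn(C)c4)nc23)ccc1CNC(=O)c1ccc(C(C)(C)C)cc1`: 0.2 10^-6 cm/s
- compound 2, `Cn1cc(-c2nc3c(-c4ccc(CNC(=O)c5nc(C6(C)CC6)no5)c(F)c4)ccnc3[nH]2)cn1`: 2.8 10^-6 cm/s
- compound 3, `Cn1cc(-c2nc3c(-c4ccc(CNC(=O)c5cc6c(s5)CCCC6)c(F)c4)ccnc3[nH]2)cn1`: 0.6 10^-6 cm/s

Compound 2 stands highest of the three in an ADME assay on Caco-2 cells (Homo sapiens) for permeability, in the apical to basolateral direction; on this read-out higher numbers stand for higher permeability and lower numbers for lower permeability. Its nearest neighbour is compound 3, with a 4.7-fold lower number from compound 2 to compound 3 (0.67 log units; beyond the scatter); the gap to compound 1 is wider still, and both gaps lie beyond the scatter.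

The step to the unmeasured compound 4, `Cn1cc(-c2nc3c(-c4ccc(CNC(=O)N5CC(OC(C)(C)C)C5)c(F)c4)ccnc3[nH]2)cn1`, is a group of 9 heavy atoms (7 carbon, 1 nitrogen, 1 oxygen; one four-membered non-aromatic ring with 1 hetero atom) in place of a group of 9 heavy atoms (6 carbon, 2 nitrogen, 1 oxygen; one three-membered non-aromatic ring of carbon only, one five-membered aromatic ring with 3 hetero atoms), on a carbonyl carbon.

For the measured compounds named here, only one measured step touches the same position, the change from compound 2 to compound 3, and it fell by a 4.7-fold lower number from compound 2 to compound 3 (0.67 log units; beyond the scatter) when the oxadiazole-bearing group was exchanged. Compound 1, which carries a different group on the carbonyl carbon and lacks the fluorine, sits lower again. Going by the values given here, both measured compounds without the oxadiazole group give smaller numbers than compound 2, so a lower number is expected for compound 4 as well, by an amount comparable to the step to compound 3 but with wide uncertainty, since no measured step involves a four-membered ring or a urea-type carbonyl.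

Compound 4 is therefore estimated at 1 10^-6 cm/s, within 0.3 10^-6 cm/s to 3 10^-6 cm/s, which is expected to correspond to a 2.8-fold lower number from compound 2 to compound 4 (0.45 log units; beyond the scatter).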

Compound 4, apparent permeability: 0.4 10^-6 cm/s
For compound 4 the middle estimate is 2.5-fold (0.40 log units) above the measured one; measured number inside the range.
By their numbers in this assay, from the lowest: compounds 1, 4 and 3 (each within the scatter of the next, the first and the last beyond it); then compound 2.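

In this assay, the group with the four-membered non-aromatic ring, which places an amide-type nitrogen on the carbonyl carbon, gives a second replacement for the group of compound 2 that ends well under it (a 7.0-fold lower number from compound 2 to compound 4 (0.85 log units; beyond the scatter)). Compounds 3 and 4 share no ring type in the varied group, yet their numbers cannot be told apart (a 1.5-fold lower number from compound 3 to compound 4 (0.18 log units; within the scatter)), so among compounds 2, 3 and 4 only compound 2, with its five-membered aromatic ring with 3 hetero atoms, stands apart, and two quite different groups read alike. No measurement at hand speaks to why this change gives this result.

The compounds shown leave open whether the number of compound 2 goes with the five-membered aromatic ring with 3 hetero atoms or with the three-membered ring of carbon only, as no compound here separates the two. Also open, as far as these compounds go, is how a morpholine or a group bearing a carboxylic acid on the same carbonyl carbon would read in this assay.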